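Lactone Series: Hydroxy to 2-Methylphenyl on the Side Chain

The compounds below may be only part of what the source reports. "The series", "measured", "known", "first", "only" and "open" are said of these compounds alone.

Measured so far:
compound 1 `O=C1C[C@@H]2O[C@@H](Cc3ccccc3)[C@@H](O)[C@@H]2O1`: 1210 nM
compound 2 `O=C1C[C@H]2O[C@H]([C@H](O)c3ccccc3)[C@H](O)[C@H]2O1`: 8320 nM

In a functional assay on HeLa cells (Homo sapiens) for antiproliferative activity, read by MTT assay, with a stated time of 72 h (on this read-out higher numbers stand for weaker inhibition and lower numbers for stronger inhibition), compound 2 gives the higher of the two numbers, and its gap to compound 1 lies beyond the scatter. Compound 3 `Cc1ccccc1[C@H](c1ccccc1)[C@H]1O[C@@H]2CC(=O)O[C@@H]2[C@H]1O` has not been measured. It differs from compound 2 by 2-methylphenyl in place of hydroxy on a saturated chain carbon bound to an aromatic carbon and a saturated ring carbon. Among the compounds with values here, no direct step between measured compounds covers this change; compound 1, which lacks the hydroxy, sits lower than compound 2, so a step downward, moderate in size, is expected in this assay. Compound 3 is therefore estimated at 2500 nM, with a range from 700 nM to 9000 nM, an expected step of a 3.3-fold lower number from compound 2 to compound 3 (0.52 log units; beyond the scatter).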

Compound 3, half-maximal inhibitory concentration: 11400 nM
Estimate against measurement, compound 3: 4.6-fold (0.66 log units) below, outside the stated range (above it).
By their numbers in this assay, from the lowest: compound 1; then compounds 2 and 3 (each within the scatter of the next).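

In this assay, 2-methylphenyl in place of hydroxy on this saturated chain carbon gives a 1.4-fold higher number from compound 2 to compound 3 (0.14 log units; within the scatter), so compound 2 and compound 3 are not separated by this read-out. At this position, the hydroxy with its hydrogen-bond donor and acceptor can thus be exchanged for an aromatic ring of seven carbons in all without a step beyond the scatter. Nothing available accounts for this result.

Still open, as far as these compounds go, is whether an amine or a carboxylic acid on this carbon would also stay within the scatter of compound 2. A longer chain in the same place also remains untested in the compounds shown.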